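This account rests on a few compounds, and the source may have more. Where it says the series, first, only, none or still open, it means among the compounds named here.

Measured so far:
compound 1 `Cc1ccc(S(=O)(=O)NCc2ccc(CNC(=O)c3ccc([N+](=O)[O-])cc3)cc2)cc1` — an assay on MDA-MB-231 cells for binding affinity to C-X-C chemokine receptor type 4 (Homo sapiens), read by immunofluorescence and microscopy, with stated times of 10 min and 30 min; a higher number here means that more compound is needed for the effect, a lower number that less compound is needed: 10 nM
compound 2 `Cc1ccc(S(=O)(=O)NCc2ccc(CNC(=O)c3ccc(Cl)cc3)cc2)cc1` — this assay: 10 nM

Compound 2 stands level with compound 1 at the digits shown; the one measured step, no change at the digits printed from compound 1 to compound 2 (within the scatter), lies within the scatter, so the two values give no order between them.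

Compound 3 `COc1ccccc1C(=O)NCc1ccc(CNS(=O)(=O)c2ccc(C)cc2)cc1` differs from compound 2 in one place: 2-methoxyphenyl in place of 4-chlorophenyl on a carbonyl carbon. Among the measured compounds shown here, the only step on record bears on the same carbonyl-linked aryl group, but it swapped one group for another on the 4-chlorophenyl ring without touching the ring itself, and it moved nothing beyond the scatter. For the measured compounds named here, the change to compound 3 is of a different kind, replacing the whole 4-chlorophenyl by 2-methoxyphenyl, so that step is only a weak guide; no measured pair shows what a 2-methoxyphenyl does here.

Given that the single known change at this position left the value unchanged, the step to compound 3 is expected to be a 1.5-fold higher number from compound 2 to compound 3 (0.18 log units; within the scatter), that is no movement beyond the scatter, but with a wide range to allow for the untested group. Compound 3 is estimated at 15 nM in this assay, within 4 nM to 60 nM.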

Compound 3, effective concentration (reported as EC, without a stated level of effect): 100 nM
Compound 3: the middle estimate sits 6.7-fold (0.82 log units) below what was measured; measured number above the stated range.
By their numbers in this assay, from the lowest: compounds 1 and 2 (each within the scatter of the next); then compound 3.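

In this assay, the aryl group on the carbonyl carbon now shows a change that moves the number beyond the scatter: a 10-fold higher number from compound 2 to compound 3 (1.00 log units; beyond the scatter), and likewise a 10-fold higher number from compound 1 to compound 3 (1.00 log units; beyond the scatter). This position is therefore not indifferent to what it carries: the swap of 4-nitrophenyl for 4-chlorophenyl left the value unchanged at the digits printed, whereas 2-methoxyphenyl in place of either group means that more compound is needed for the effect. No measurement at hand accounts for this difference.

The step from 4-chlorophenyl to 2-methoxyphenyl changes both the substituent and the number in the group's name, so the compounds shown cannot separate the contribution of the methoxy group from that of its placement; 4-methoxyphenyl and 2-chlorophenyl would divide the two. Also open, from the compounds shown here alone, is how an unsubstituted phenyl, or a ring bearing an amine or a carboxylic acid, would compare on this carbonyl carbon, and whether any group here can give a lower number than compound 1 and compound 2.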